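Swapping a Pentyl Chain for Fluorine on the Aryl Ring

This account rests on a few compounds, and the source may have more. Where it says the series, first, only, none or still open, it means among the compounds named here.

Three close relatives sharing one core have been tested in a functional assay on FTC-133 cells (Homo sapiens) for cytotoxicity, read by MTT assay, with a stated time of 24 h; on this read-out higher numbers stand for weaker inhibition and lower numbers for stronger inhibition. Compound 1 `CN1O[C@@H](n2cc(-c3ccc(F)cc3)nn2)C[C@@H]1CO` carries a fluoro group on its aryl ring, and in this assay compound 1 gives 6070 nM. Compound 2 `COc1ccc(-c2cn([C@@H]3C[C@H](CO)N(C)O3)nn2)cc1` carries a methoxy group instead, and compound 2 gives 6480 nM. Compound 3 `CCCCCc1ccc(-c2cn([C@@H]3C[C@H](CO)N(C)O3)nn2)cc1` carries a pentyl chain, and compound 3 gives 4490 nM. Compound 3 thus holds the lowest of the three numbers, but its gaps to compound 1 and to compound 2 are both within the usual scatter, so none of the three can be called stronger or weaker than another.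

Compound 4 `CN1O[C@H](n2cc(-c3ccc(F)cc3)nn2)C[C@@H]1CO` has not yet been measured. Compared with compound 3, the change is fluoro in place of pentyl on an aromatic carbon. Going by the values given here, the one measured step at this position, a 1.4-fold lower number from compound 2 to compound 3 (0.16 log units; within the scatter), shows that exchanging one group for another on this aromatic carbon barely moved the number. Compound 1, which also carries fluoro, sits close to compound 3 as well. The step of a 1.2-fold higher number from compound 3 to compound 4 (0.09 log units; within the scatter) is therefore expected to stay within the scatter. For compound 4 the estimated value in this assay is 5500 nM, with a range from 2500 nM to 12000 nM.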

Compound 4, half-maximal inhibitory concentration: 5850 nM
Estimate against measurement, compound 4: 1.1-fold (0.03 log units) below, within the range that was stated.
By their numbers in this assay, from the lowest: compounds 3, 4, 1 and 2 (each within the scatter of the next).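

At the aromatic carbon para to a large group, the step of a 1.3-fold higher number from compound 3 to compound 4 (0.11 log units; within the scatter) removes a pentyl chain of 5 carbons and puts a single fluorine there, yet it stays as small as the earlier step between methoxy and pentyl. The step of a 1.1-fold lower number from compound 2 to compound 4 (0.04 log units; within the scatter) completes the set, so in this assay fluoro, methoxy and pentyl on this carbon all lie within the scatter of one another, which the earlier compounds had shown only for methoxy and pentyl. New in kind is the step of a 1.0-fold lower number from compound 1 to compound 4 (0.02 log units; within the scatter) with a stereocentre at a saturated ring carbon drawn R in compound 1 and S in compound 4, and this pair shows that changing this one centre leaves the number within the scatter, a reading that is clean for one reason: the fact that compounds 1 and 4 differ only in the configuration as drawn.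

Still open, from the compounds shown here alone, is whether an amine, a carboxylic acid or a chain longer than pentyl on this aromatic carbon would move the number beyond the scatter. Also open, going by these compounds, is whether changing the second stereo element of the shared core, alone or together with the first, would leave the number as unmoved as this single change did.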